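Swapping Butyl for Isopropyl: A Small Step Expected

The compounds below may be only part of what the source reports. "The series", "measured", "known", "first", "only" and "open" are said of these compounds alone.

Of the compounds shown here, three have been measured, each built around a thiocarbonyl carbon bonded to two amide-type nitrogens. In a functional assay on RAW264.7 cells (Mus musculus) for inhibition, read by Griess assay, with a stated time of 24 h (a higher number here means a weaker inhibitor, a lower number a stronger inhibitor), compound 2 `COc1cc(NC(=S)Nc2cc(OC)c(OC)c(OC)c2)cc(OC)c1OC` gives 31800 nM. Compound 3 `CCCCNC(=S)NCc1ccccc1` gives 143000 nM, the higher of the two numbers, and its distance from compound 2 lies beyond the usual scatter of repeated measurements. For compound 1 `OCCNC(=S)Nc1ccccc1` this assay reports only a limit, >= 200000 nM, so it is not a number that can be set against the others; that limit is the limit of >= 200000 nM in this assay, at which 1 of the 3 values shown sits.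

Compound 4 `CC(C)NC(=S)NCc1ccccc1` is the next case. It is compound 3 with one change: isopropyl in place of butyl on an amide-type nitrogen. For the measured compounds named here, no measured pair here shows what such a change does, so the expectation rests on the step being small. Compound 4 is estimated at 160000 nM in this assay, with a likely range from 75000 nM to 320000 nM. That estimate means a step of a 1.1-fold higher number from compound 3 to compound 4 (0.05 log units; within the scatter), expected to stay within the scatter, in no clear direction.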

Compound 4, half-maximal inhibitory concentration: >= 200000 nM
Compound 4: a limit, no number (the forecaster's own chance of this, stated with the estimate: 35%); middle value at least 1.2-fold (0.09 log units) away from the limit.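

In this assay compound 4 reads only as a limit of the assay, not as a number, so this first pair differing in one place gives a floor for the step rather than its size: an at least 1.3-fold higher number from compound 3 to compound 4 (0.14 log units; that floor lies within the scatter). Isopropyl in place of butyl on this amide-type nitrogen therefore shows no sign of a stronger inhibitor, though how far the number rises remains unknown. Compound 4 now shares this limit with compound 1, so the limit has become a common outcome among the compounds shown: the limit of >= 200000 nM in this assay, at which 2 of the 4 values shown sit.

Still open, as far as these compounds go, is whether any group on this nitrogen can bring the number down, such as a longer chain like hexyl, a cyclohexyl ring or a chain ending in an amine. Also open, from the compounds shown here alone, is whether the benzyl group on the other nitrogen matters more than the butyl or isopropyl group does.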